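Swapping an Ethyl Ester for a Cyclohexyl Ester

The source may hold more compounds than are shown below. What is called first, only, known or untested is meant among the compounds shown, and "the series" means these compounds.

Compound 1 `Cc1cc(NC(=O)c2cnc(Cl)nc2C(F)(F)F)on1` gives 4000 nM in an assay on Jurkat cells for inhibition of nuclear factor NF-kappa-B p105 subunit (Homo sapiens); on this read-out lower numbers stand for stronger inhibition and higher numbers for weaker inhibition.
Compound 2 `CCCCNC(=O)c1cc(NC(=O)c2cnc(Cl)nc2C(F)(F)F)cc(C(F)(F)F)c1` gives > 10000 nM in this assay; this is a limit of the assay, not a number.
Compound 3 `CCOC(=O)c1cc(NC(=O)c2cnc(Cl)nc2C(F)(F)F)cc(C(F)(F)F)c1` gives 280 nM in this assay.

Of the two numbers shown, compound 3 has the lowest; compound 1 sits higher by a gap beyond the usual scatter, and compound 2 reaches only (the limit of > 10000 nM in this assay, at which 1 of the 3 values shown sits). Going by the values given here, the single measured step on the carbonyl, an at least 35-fold lower number from compound 2 to compound 3 (1.55 log units; beyond the scatter), replaced an amide by an ester, with a large drop in the number.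

Compound 4 `O=C(OC1CCCCC1)c1cc(NC(=O)c2cnc(Cl)nc2C(F)(F)F)cc(C(F)(F)F)c1` keeps that ester but changes the group on its oxygen: cyclohexyl in place of ethyl on an oxygen next to a carbonyl group. Among the compounds with values here, no measured step varies the size of the group on the ester oxygen; the step of an at least 35-fold lower number from compound 2 to compound 3 (1.55 log units; beyond the scatter) concerns the amide-to-ester swap and does not speak to ethyl versus cyclohexyl. With no bearing evidence, the expected step is none beyond the scatter, a 1.1-fold higher number from compound 3 to compound 4 (0.03 log units; within the scatter), though the range is kept wide. Compound 4 is therefore estimated at 300 nM, expected between 80 nM and 1500 nM.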

Compound 4, half-maximal inhibitory concentration: 1800 nM
For compound 4 the middle estimate is 6.0-fold (0.78 log units) below the measured one; the whole stated range lies below it.
By their numbers in this assay, from the lowest: compound 3; then compound 4; then compound 1. At a limit, above all of these: compound 2.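

Cyclohexyl in place of ethyl on an oxygen next to a carbonyl group is not a silent change in this assay: the step is a 6.4-fold higher number from compound 3 to compound 4 (0.81 log units; beyond the scatter), so the group on the ester oxygen matters as well as the ester itself. The ester still keeps a clear edge over the amide with the larger group in place, with an at least 5.5-fold lower number from compound 2 to compound 4 (0.74 log units; beyond the scatter). Compound 2 stands here as a limit of the assay and not a number: the limit of > 10000 nM in this assay, at which 1 of the 4 values shown sits.

With only ethyl and cyclohexyl on this oxygen, the compounds shown cannot separate the effect of the ring from that of the carbon count, a question that a hexyl or isopropyl ester could address. Going by these compounds, how a methyl ester or the free carboxylic acid would read at this place also remains open.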